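A few compounds are considered here, and "the series" means these few. Any claim that something is new, unique, unknown or untested is made for them only; others in the source may bear on it.

Working notes on the series.

Of the compounds shown here, two have numbers so far. Compound 1 `O=C(O)CCCCOc1ccc2c(=O)c(-c3ccc(O)cc3)coc2c1` gives 100 nM in an assay (Cricetulus griseus) for inhibition of aldehyde dehydrogenase, mitochondrial (Homo sapiens); on this read-out higher numbers stand for weaker inhibition and lower numbers for stronger inhibition. Compound 2 `CCOc1ccc2c(=O)c(-c3ccc(O)cc3)coc2c1` gives 80 nM in this assay; this is the lowest of the two numbers, but its nearest neighbour is compound 1, and the step of a 1.3-fold lower number from compound 1 to compound 2 (0.10 log units; within the scatter) lies within the scatter, so no order between the two can be read.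

Compound 3 `O=c1c(-c2ccc(O)cc2)coc2cc(OCCCCCCCCCO)ccc12` has not been measured. It differs from compound 2 by 7-hydroxyheptyl in place of hydrogen on a saturated chain carbon, two bonds along the chain from an oxygen on an aromatic ring. Going by the values given here, the one measured step that touches the same place is the one from compound 1 to compound 2, where 2-carboxyethyl was exchanged for hydrogen at that chain carbon, and it moved the number by a 1.3-fold lower number from compound 1 to compound 2 (0.10 log units; within the scatter), inside the scatter. Among the compounds with values here, the chain entering in compound 3 is longer than the one compound 1 carried and ends in a hydroxyl rather than a carboxylic acid, so the precedent is only partial. On this basis the step from compound 2 to compound 3 is expected to be a 1.3-fold higher number from compound 2 to compound 3 (0.10 log units; within the scatter), without a clear direction beyond the scatter. Compound 3 is therefore estimated at 100 nM in this assay, with a range of 40 nM to 250 nM.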

Compound 3, half-maximal inhibitory concentration: 700 nM
The estimate for compound 3 lay 7.0-fold (0.85 log units) below the measured number; measured number above the stated range.
By their numbers in this assay, from the lowest: compounds 2 and 1 (each within the scatter of the next); then compound 3.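

At this chain carbon, the series is no longer flat: in this assay the exchange of hydrogen for 7-hydroxyheptyl gives an 8.8-fold higher number from compound 2 to compound 3 (0.94 log units; beyond the scatter), beyond the scatter, while the exchange of hydrogen for 2-carboxyethyl at the same carbon stayed within it. The chain carbon therefore does not accept every extension alike, and a higher number, meaning weaker inhibition, is now tied to one specific chain. The exchange of carboxy for 5-hydroxypentyl further out on the chain gives a 7.0-fold higher number from compound 1 to compound 3 (0.85 log units; beyond the scatter), so compound 3 stands apart from both earlier compounds, and no measurement on hand bears on the cause of this result.

The compounds shown leave open whether the higher number goes with the length of the chain or with its terminal hydroxyl, since these two differ together between compound 1 and compound 3. A plain alkyl chain of the same length, a carboxylic acid or an amine at the end of a chain of this length, and chains of intermediate length would each bear on that question.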